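The source may hold more compounds than are shown below. What is called first, only, known or untested is meant among the compounds shown, and "the series" means these compounds.

Measured so far in a functional assay on HEK293 cells for agonist activity at Bile acid receptor (Homo sapiens); on this read-out higher numbers stand for larger maximal responses and lower numbers for smaller maximal responses:
compound 1 `CN(Cc1cccc(C(=O)O)c1)c1ccc(OCc2c(-c3c(Cl)cccc3Cl)noc2C2CC2)nc1C(F)(F)F` — 79%
compound 2 `O=C(O)c1ccc(OCc2ccc(OCc3c(-c4c(Cl)cccc4Cl)noc3C3CC3)nc2C(F)(F)F)cc1` — 59%

For the measured compounds named here, compound 2 stands lowest of the two numbers; its only neighbour is compound 1, and the gap between them is a number 20 percentage points lower from compound 1 to compound 2 (beyond the scatter). Going by the values given here, that is the only step known. It exchanged (3-carboxybenzyl)(methyl)amino for (4-carboxyphenoxy)methyl on the same aromatic carbon and brought a modest loss in maximal response.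

Compound 3 `CC(Oc1cccc(C(=O)O)c1)c1ccc(OCc2c(-c3c(Cl)cccc3Cl)noc2C2CC2)nc1C(F)(F)F` is not yet measured. It differs from compound 2 by 1-(3-carboxyphenoxy)ethyl in place of (4-carboxyphenoxy)methyl on an aromatic carbon. Among the compounds with values here, the single measured step bears on this only loosely: it shows that the arm on this carbon matters for efficacy in this assay, and that the 3-carboxy arrangement, as in compound 1, went with the higher of the two numbers. Whether the added methyl on the linking carbon or the 3-carboxyphenoxy arrangement carries weight cannot be separated with two compounds. The step is therefore estimated as a number 11 percentage points higher from compound 2 to compound 3 (beyond the scatter), upward and small. Compound 3 is estimated at 70%, with a likely range from 52% to 88%.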

Compound 3, largest response reached (reported as efficacy), in percent of the reference or control that the assay uses: 50%
Estimate against measurement, compound 3: 20 percentage points above; measured number outside the range, below it.
By their numbers in this assay, from the lowest: compounds 3 and 2 (each within the scatter of the next); then compound 1.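

On this aromatic carbon, ortho to a trifluoromethyl group, this assay gives a number 9 percentage points lower from compound 2 to compound 3 (within the scatter) for the exchange of (4-carboxyphenoxy)methyl for 1-(3-carboxyphenoxy)ethyl, so these two arms cannot be told apart on this read-out. The 3-carboxy arrangement alone therefore does not go with the higher number: the arms of compound 1 and compound 3 both carry it, yet the step reads a number 29 percentage points lower from compound 1 to compound 3 (beyond the scatter) on replacing (3-carboxybenzyl)(methyl)amino with 1-(3-carboxyphenoxy)ethyl, and among the three compounds only the arm with the amine link stands apart from the others beyond the scatter. Nothing measured here gives a reason for these differences.

A (3-carboxyphenoxy)methyl arm would separate the methyl on the linking carbon from the placement of the carboxylic acid, a pair of effects that may be cancelling or both absent in the present step. Also open, as far as these compounds go, is whether the higher maximal response of compound 1 follows the tertiary amine itself, so that a secondary amine or an amide link at the same place would show whether the nitrogen or its methyl matters.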